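The compounds below may be only part of what the source reports. "The series", "measured", "known", "first", "only" and "open" are said of these compounds alone.

Measured in a functional assay on OVCAR-3 cells (Homo sapiens) for antiproliferative activity, read by MTT assay, with a stated time of 24 h; a higher number here means a weaker inhibitor, a lower number a stronger inhibitor:
- compound 1 `Cc1ccccc1NNC(=O)c1ccccc1NS(=O)(=O)c1cnc(O)nc1O`: > 20000 nM (a limit)
- compound 2 `O=C(NNC(=O)c1ccccc1NS(=O)(=O)c1cnc(O)nc1O)c1ccccc1Cl`: 18200 nM

Going by the values given here, compound 2, at 18200 nM, holds the only actual number. Compound 1 reports only a limit. Compound 3 `O=C(NNC(=O)c1ccccc1NS(=O)(=O)c1cnc(O)nc1O)c1ccc(F)cc1` puts 4-fluorophenyl in place of 2-chlorophenyl on a carbonyl carbon. Among the compounds with values here, the sole measured step, an at least 1.0-fold lower number from compound 1 to compound 2 (0.04 log units; that floor lies within the scatter), is a different change, rests on a limit and stays within the scatter. On that basis no step beyond the scatter is expected in this assay, and no direction can be favoured. The expected step is a 1.1-fold lower number from compound 2 to compound 3 (0.06 log units; within the scatter). Compound 3 is estimated at 16000 nM, with an expected range of 7000 nM to 35000 nM.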

Compound 3, half-maximal inhibitory concentration: 15100 nM
Beside the measured number, compound 3's estimate is 1.1-fold (0.03 log units) above it; measured number inside the range.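

In this assay, 4-fluorophenyl in place of 2-chlorophenyl on a carbonyl carbon gives a 1.2-fold lower number from compound 2 to compound 3 (0.08 log units; within the scatter), so these two groups are not told apart at this position, which compound 2 alone could not show. Compound 1 is known only as a limit: the limit of > 20000 nM in this assay, at which 1 of the 3 values shown sits. Its step, an at least 1.3-fold lower number from compound 1 to compound 3 (0.12 log units; that floor lies within the scatter), gives only a floor and no size for that change.

Going by these compounds, since the halogen and its ring position change together, their separate contributions remain open. Also open, on these data alone, is whether a carboxylic acid, an amine or a longer chain at this position would move the number beyond the scatter.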